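Iodo in place of chloro on the phenyl amide

The source may report more compounds than this note shows. Statements on the series, on what has been measured and on what is new or still open speak of the compounds shown alone.

Values in a functional assay on MDA-MB-231 cells (Homo sapiens) for antiproliferative activity, read by MTT assay, with a stated time of 72 h (on this read-out lower numbers stand for stronger inhibition and higher numbers for weaker inhibition), so far
Compound 1 `O=C(CCc1cccc2c1B(O)OC2)NCc1ccccc1` gives > 100000 nM (a limit)
Compound 2 `O=C(CCc1cccc2c1B(O)OC2)Nc1nccs1` gives > 100000 nM (a limit)
Compound 3 `O=C(CCc1cccc2c1B(O)OC2)Nc1ccc(Cl)cc1` gives 3600 nM (a number)

Within the data shown here, compound 3 holds the only true number in the set. The other two stand at the limit of > 100000 nM in this assay, at which 2 of the 3 values shown sit, and are limits only. Compound 4 `O=C(CCc1cccc2c1B(O)OC2)Nc1ccc(I)cc1` carries iodo in place of chloro on an aromatic carbon. The steps nearest to it are an at least 27-fold lower number from compound 1 to compound 3 (1.44 log units; beyond the scatter) and an at least 27-fold lower number from compound 2 to compound 3 (1.44 log units; beyond the scatter) but both exchange the whole group on the amide-type nitrogen and neither varies the halogen. The expectation therefore stays close to compound 3 at 3600 nM and no large shift is assumed. The expected change is a 1.2-fold lower number from compound 3 to compound 4 (0.08 log units; within the scatter) and no step beyond the scatter is expected in either direction. Compound 4 is estimated at 3000 nM with an expected range from 1000 nM to 10000 nM in this series.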

Compound 4, half-maximal inhibitory concentration: 33000 nM
The estimate for compound 4 lay 11-fold (1.04 log units) below the measured number; measured number above the stated range.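

In this assay, among these compounds, the identity of the halogen on the phenyl amide proves to matter, with a 9.2-fold higher number from compound 3 to compound 4 (0.96 log units; beyond the scatter), whereas the earlier steps only exchanged the whole group on the amide nitrogen. The 4-iodophenyl amide still keeps an advantage over the other two amide groups, with an at least 3.0-fold lower number from compound 1 to compound 4 (0.48 log units; beyond the scatter) and an at least 3.0-fold lower number from compound 2 to compound 4 (0.48 log units; beyond the scatter). Both of these steps are bounded by limits rather than numbers: the limit of > 100000 nM in this assay, at which 2 of the 4 values shown sit.

With only chloro and iodo shown, it remains open how fluoro, bromo, methoxy or an amine would read at this place. As far as these compounds go, what drives the step from chloro to iodo also stays open.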